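Oxadiazole aryl swap on the shared core

The source may hold more compounds than are shown below. What is called first, only, known or untested is meant among the compounds shown, and "the series" means these compounds.

Measured so far:
compound 1, `CS(=O)(=O)c1ccc(-c2cnc3[nH]cc(-c4nnc(-c5ccc(F)cc5)o4)c(=O)c3c2)cc1`, 18.7%
compound 2, `O=c1c(-c2nnc(-c3ccc(F)cc3)o2)c[nH]c2ncc(-c3ccncc3)cc12`, 20.5%

Both numbers come from a functional assay on HCT-116 cells (Homo sapiens) for inhibition, read by MTT assay, with a stated time of 24 h, tested at 10 uM; a higher number here means more inhibition of growth at the concentration tested, a lower number less inhibition of growth. Compound 1 gives 18.7% and compound 2 gives 20.5%; the two values lie within the scatter of each other, as the step of a number 1.8 percentage points higher from compound 1 to compound 2 (within the scatter) shows, so neither compound can be set apart from the other on this read-out.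

Compound 3 is `Cc1cccc(-c2nnc(-c3c[nH]c4ncc(-c5ccc(S(C)(=O)=O)cc5)cc4c3=O)o2)c1`, not yet measured. The change from compound 1 is 3-methylphenyl in place of 4-fluorophenyl on an aromatic carbon. Within the data shown here, the only measured step, from compound 1 to compound 2, changes a different part of the molecule, the group on the shared core rather than the aryl on the five-membered ring, and it stays within the scatter. Among the measured compounds shown here, no measured step touches the place changed in compound 3, so there is nothing to point to a shift in either direction.

Compound 3 is therefore expected to sit close to compound 1, with an estimated step of a number 1.3 percentage points higher from compound 1 to compound 3 (within the scatter) in this assay , i.e. none beyond the scatter. The estimate for compound 3 is 20%, in a range from 5% to 40%.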

Compound 3, percent growth inhibition at one concentration: 25.2%
For compound 3 the middle estimate is 5.2 percentage points below the measured one; the range from low to high includes it.
By their numbers in this assay, from the lowest: compounds 1, 2 and 3 (each within the scatter of the next).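

In this assay, among these compounds, the exchange of 4-fluorophenyl for 3-methylphenyl on the aromatic carbon of the five-membered ring gives the first reading at this position: a number 6.5 percentage points higher from compound 1 to compound 3 (within the scatter). The two groups match in the counts computed for them, with the same number of heavy atoms and one six-membered aromatic ring of carbon only, and they differ in a fluorine substituent against a methyl substituent and in where that substituent sits on the phenyl ring; on this read-out, that difference does not set compound 3 apart from compound 1, so the position accepts either group without a change that can be told from the scatter. No accompanying measurement bears on why the reading falls where it does.

Still open, from the compounds shown here alone, is whether a phenyl ring carrying an amine or a carboxylic acid at this position, or a longer alkyl chain in place of the phenyl ring, would move the number in this assay beyond the scatter. Also open, going by these compounds, is whether 3-methylphenyl on the oxadiazole side and pyridin-4-yl on the shared core, carried together in one molecule, would read any differently from compound 2 or compound 3.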